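Compound 3: 4-fluorophenyl in place of 2,2,2-trifluoroethyl

The compounds below may be only part of what the source reports. "The series", "measured", "known", "first", "only" and "open" are said of these compounds alone.

In a functional assay on A2780 cells (Homo sapiens) for antiproliferative activity, read by CellTiter-Glo, with a stated time of 4 days (on this read-out higher numbers stand for weaker inhibition and lower numbers for stronger inhibition), compound 1 (`O=C(NCc1cccnc1)Nc1ccc(CN2C(=O)c3ccccc3C2=O)cc1`) gives 100 nM and compound 2 (`C[C@H](NC(=O)CC(F)(F)F)c1ccc(NC(=O)[C@H]2C[C@@H]2c2cccnc2)cc1`) gives 5 nM as the lower of the two numbers, a gap beyond the scatter. Compound 3 (`C[C@H](NC(=O)c1ccc(F)cc1)c1ccc(NC(=O)[C@H]2C[C@@H]2c2cccnc2)cc1`) has 4-fluorophenyl in place of 2,2,2-trifluoroethyl on a carbonyl carbon. Among the compounds with values here, no measured pair shows this change, so the expectation rests only on compound 2 at 5 nM as the starting point. Expected in this assay is a 1.2-fold higher number from compound 2 to compound 3 (0.08 log units; within the scatter) and thus no change beyond the scatter. For compound 3 the estimated value is 6 nM with 1.5 nM to 25 nM as the expected range.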

Compound 3, half-maximal inhibitory concentration: 2 nM
Compound 3: middle estimate off by 3.0-fold (0.48 log units), on the high side; the range from low to high includes it.
By their numbers in this assay, from the lowest: compound 3; then compound 2; then compound 1.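

On this assay the carbonyl carbon bearing the amide-type nitrogen accepts an aromatic ring in place of a fluorinated alkyl chain: 4-fluorophenyl in place of 2,2,2-trifluoroethyl gives a 2.5-fold lower number from compound 2 to compound 3 (0.40 log units; beyond the scatter) and so a modest gain rather than a loss. Within the data shown here, this is the first reading of a change at this position. No measurement at hand accounts for the step.

Going by these compounds, what the ring alone contributes, apart from its fluorine, remains open. Unsubstituted phenyl or cyclohexyl on the same carbonyl would separate the two.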